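This account rests on a few compounds, and the source may have more. Where it says the series, first, only, none or still open, it means among the compounds named here.

In an ADME assay on microsomes from liver (Mus musculus) for pharmacokinetics, read by LC-MS, using NADPH, with stated times of 5 min, 15 min and 30 min, tested at 10 uM (a higher number here means faster removal of the compound, a lower number slower removal), compound 3 (`C[C@H](NC(=O)C1CCOCC1)c1ccc(NC(=O)N2CC(c3ccc(N)nc3)C2)cc1`) is known only as a limit, < 25 mL.min-1.g-1 and not as a number. Compound 2 (`C[C@H](NC(=O)c1cccc(F)c1)c1ccc(NC(=O)N2CC(c3ccc(N)nc3)C2)cc1`) also returns just a limit, < 25 mL.min-1.g-1 with no number behind it. Only compound 1 (`CCC(=O)N[C@@H](C)c1ccc(NC(=O)N2CC(c3cccnc3)C2)cc1`) gives a true number in this set, 31.4 mL.min-1.g-1 in this assay and this is the single firm point available.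

Compound 4 (`CCC(=O)N[C@@H](C)c1ccc(NC(=O)N2CC(c3ccc(N)nc3)C2)cc1`) comes from compound 3 through one change: ethyl in place of oxan-4-yl on a carbonyl carbon in words, ethyl in place of oxan-4-yl on a carbonyl carbon, so that (oxan-4-yl)carbonyl becomes propanoyl. The rest of the molecule stays as it is.

For the measured compounds named here, the one measured step at this same place is a step that the two limits leave unreadable from compound 2 to compound 3 and its size cannot be read. It therefore offers no guide to how large the new step will be. Compound 4 shares its propanoyl with compound 1, whose 31.4 mL.min-1.g-1 is the closest real number, although the two differ elsewhere on the core.

On this thin evidence, no step beyond the usual scatter is expected in this assay in either direction. The estimated change is a number no lower from compound 3 to compound 4 (the limit leaves the size open) and it remains an expectation only. For compound 4 the expected value is 25 mL.min-1.g-1 with an estimated range from 14 mL.min-1.g-1 to 42 mL.min-1.g-1 and the result may well come back as a limit alone.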

Compound 4, intrinsic clearance in microsomes: 22 mL.min-1.g-1
For compound 4 the middle estimate is 1.1-fold (0.06 log units) above the measured one; the range from low to high includes it.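

Compound 4 is the first compound shown that carries the amino group and returns a true number rather than a limit, which makes a direct comparison with compound 1 possible. In this assay, amino in place of hydrogen on an aromatic carbon, with the propanoyl group and the rest of the molecule unchanged, gives a 1.4-fold lower number from compound 1 to compound 4 (0.15 log units; within the scatter), so this one change has no effect on removal that can be told apart from the noise of the measurement. The steps from compound 2 and from compound 3 to compound 4 cannot be read, so the exchange of oxan-4-yl or 3-fluorophenyl for ethyl on the carbonyl carbon still has no size, because those two compounds are known only as a limit: the limit of < 25 mL.min-1.g-1 in this assay, at which 2 of the 4 values shown sit.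

On these data alone, it remains open whether a longer chain such as butyl on that carbonyl carbon would give a number clearly apart from that of compound 4. As far as these compounds go, it is equally open whether another group in place of the amino group on the aromatic carbon, such as a methyl group or a carboxylic acid, would leave removal as little changed.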